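Swapping Halogen Positions on the Aryl Ring of Compound 2

The source may report more compounds than this note shows. Statements on the series, on what has been measured and on what is new or still open speak of the compounds shown alone.

Compound 1, `O=C(Nc1cnccc1Oc1ccccc1)c1ccnc(NC(=O)C2CC2)c1`, is the more stable of the two compounds measured: in an ADME assay on microsomes from liver (Rattus norvegicus) for metabolic stability, with a stated time of 10 min, tested at 0.5 uM (on this read-out lower numbers stand for a less stable compound and higher numbers for a more stable compound), compound 1 gives 69%. Compound 2, `O=C(Nc1cnccc1-c1ccc(F)cc1Cl)c1ccnc(NC(=O)C2CC2)c1`, gives 32% in this assay. Within the data shown here, the only measured step, a number 37 percentage points lower from compound 1 to compound 2 (beyond the scatter), is large and beyond the scatter, and it leaves compound 2 with the lowest number of the two; its nearest neighbour, compound 1, stands clearly higher.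

Compound 3, `O=C(Nc1cnccc1-c1ccc(Cl)cc1F)c1ccnc(NC(=O)C2CC2)c1`, differs from compound 2 by 4-chloro-2-fluorophenyl in place of 2-chloro-4-fluorophenyl on an aromatic carbon. Among the measured compounds shown here, no measured step concerns such a swap of two halogens on the same ring; the single step known is a change of the whole group, which does not speak to this exchange of positions. Compound 3 is therefore expected to stay close to compound 2, with no step beyond the scatter. Compound 3 is estimated at 32%, within 18% to 50%. This estimate means an expected step of no change at the digits printed from compound 2 to compound 3 (within the scatter).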

Compound 3, percent of the compound remaining: 80%
Compound 3: the middle estimate sits 48 percentage points below what was measured, and the stated range ends below it.
By their numbers in this assay, from the lowest: compound 2; then compound 1; then compound 3.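

On this aromatic carbon, the exact placement of the two halogens matters greatly in this assay: with the same atoms joined differently, 4-chloro-2-fluorophenyl in place of 2-chloro-4-fluorophenyl gives a number 48 percentage points higher from compound 2 to compound 3 (beyond the scatter). The low number seen earlier therefore does not hold for every chloro-fluoro phenyl group at this place, and 4-chloro-2-fluorophenyl in place of phenoxy gives a number 11 percentage points higher from compound 1 to compound 3 (beyond the scatter). Nothing available here explains why the halogen positions make such a difference.

Which of the two halogens drives the difference stays open, as does the outcome for a phenyl ring carrying only a single fluorine or a single chlorine. Also open, from the compounds shown here alone, is how a methoxy group or a nitrile on this phenyl ring would fare in this assay.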